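This account rests on a few compounds, and the source may have more. Where it says the series, first, only, none or still open, it means among the compounds named here.

Measured compounds:
compound 1, `CCCc1nnn(Cc2ccc(C(F)(F)F)cc2)c1C(=O)N[C@@H](C)c1ccc(C(=O)O)cc1`: 68.8 nM
compound 2, `C[C@H](NC(=O)c1c(C2CCCCC2)nnn1Cc1ccc(C(F)(F)F)cc1)c1ccc(C(=O)O)cc1`: 161 nM

In a functional assay on CHO cells for antagonist activity at prostaglandin E2 receptor EP4 subtype (Homo sapiens), read by calcium flux, with a stated time of 15 min (on this read-out lower numbers stand for stronger inhibition and higher numbers for weaker inhibition), compound 2 gives the higher of the two numbers, with compound 1 giving a lower number by a 2.3-fold higher number from compound 1 to compound 2 (0.37 log units; beyond the scatter). Compound 3, `C[C@H](NC(=O)c1c(C2=CCOCC2)nnn1Cc1ccc(C(F)(F)F)cc1)c1ccc(C(=O)O)cc1`, differs from compound 2 in that (a group of 6 heavy atoms (5 carbon, 1 oxygen; one six-membered non-aromatic ring with 1 hetero atom) in place of a group of 6 heavy atoms (6 carbon; one six-membered non-aromatic ring of carbon only), on an aromatic carbon). Among the compounds with values here, no measured step covers this exchange; the only step known, from propyl to cyclohexyl, is modest and concerns a different change. For compound 3 a step of a 1.1-fold lower number from compound 2 to compound 3 (0.03 log units; within the scatter) is therefore expected, within the scatter. Compound 3 is estimated at 150 nM in this assay, with a range from 50 nM to 450 nM.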

Compound 3, half-maximal inhibitory concentration: 119 nM
Estimate against measurement, compound 3: 1.3-fold (0.10 log units) above; the range from low to high includes it.
By their numbers in this assay, from the lowest: compounds 1, 3 and 2 (each within the scatter of the next, the first and the last beyond it).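

In this assay the oxygen-bearing six-membered ring, with its double bond and hydrogen-bond acceptor, stands in place of cyclohexyl on the aromatic carbon and gives a 1.4-fold lower number from compound 2 to compound 3 (0.13 log units; within the scatter) so this position accepts a ring oxygen with no step beyond the scatter. Against propyl the same group gives a 1.7-fold higher number from compound 1 to compound 3 (0.24 log units; within the scatter) and so, unlike cyclohexyl, does not separate from propyl beyond the scatter. Nothing available explains this result.

Open, on these data alone, is whether the ring oxygen or the double bond accounts for the small step, which a saturated tetrahydropyranyl group could separate. Also open, as far as these compounds go, is how an amine or a carboxylic acid at this position would read.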